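This account rests on a few compounds, and the source may have more. Where it says the series, first, only, none or still open, it means among the compounds named here.

Three members of the series, compound 1 `Cc1ccc2[nH]c(=O)c(CN(Cc3ccc(F)cc3)Cc3ccc(C(C)(C)C)cc3)cc2c1`, compound 2 `CCCCOc1ccc(CN(Cc2ccc(C(C)(C)C)cc2)Cc2cc3cc(C)ccc3[nH]c2=O)cc1` and compound 3 `Cc1ccc2[nH]c(=O)c(CN(Cc3ccc(C(N)=O)cc3)Cc3ccc(C(C)(C)C)cc3)cc2c1`, all stop at a limit of the assay in a toxicity assay on MDCK cells (Canis lupus familiaris) for cytotoxicity, read by crystal violet staining, with a stated time of 48 h; on this read-out lower numbers stand for higher toxicity in this test and higher numbers for lower toxicity in this test. Compound 1 gives the limit > 27000 nM. Compound 2 gives the limit > 5000 nM. Compound 3 gives the limit > 5000 nM, so where compound 3 stands among the numbers shown is known only as a limit, as are the two other values. Compound 4 `Cc1ccc2[nH]c(=O)c(CN(Cc3ccc(OCCO)cc3)Cc3ccc(C(C)(C)C)cc3)cc2c1` carries the change (2-hydroxyethoxy in place of carbamoyl on an aromatic carbon). Among the compounds with values here, the steps that bear on it, a step that the two limits leave unreadable from compound 1 to compound 2, a step that the two limits leave unreadable from compound 1 to compound 3 and a step that the two limits leave unreadable from compound 2 to compound 3, stay unreadable between the limit of > 27000 nM in this assay, at which 1 of the 3 values shown sits, and (the limit of > 5000 nM in this assay, at which 2 of the 3 values shown sit), so for a step that the limit leaves unreadable from compound 3 to compound 4 no direction beyond the scatter is expected. Compound 4 is estimated at 20000 nM, between 5000 nM and 80000 nM, most likely reported again as a limit.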

Compound 4, half-maximal cytotoxic concentration: > 5000 nM
Compound 4: only a limit was reported (the forecaster's own chance of this, stated with the estimate: 85%); the middle value does not contradict the limit.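

The steps from compound 1, compound 2 and compound 3 to compound 4 cannot be read in this assay, as all four compounds stop at limits of the assay. Left open is whether fluoro, butoxy, carbamoyl and 2-hydroxyethoxy differ at all on this read-out, and at what concentration any of the four compounds becomes cytotoxic.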